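A few compounds are considered here, and "the series" means these few. Any claim that something is new, unique, unknown or untested is made for them only; others in the source may bear on it.

Measured in a functional assay on HL-60 cells (Homo sapiens), with a stated time of 4 days; a lower number here means a stronger inhibitor, a higher number a weaker inhibitor:
- compound 1 `CCCCCCNC(=O)c1[nH]cnc1C(=O)Nc1ccc(Cl)c(Cl)c1`: 7800 nM
- compound 2 `C[C@@H](NC(=O)c1[nH]cnc1C(=O)Nc1ccc(Cl)c(Cl)c1)C(=O)OC(C)(C)C`: 2500 nM

Compound 2, at 2500 nM, holds the lower of the two numbers in this assay. The next change gives compound 3 `COC(=O)[C@@H](NC(=O)c1[nH]cnc1C(=O)Nc1ccc(Cl)c(Cl)c1)C(C)C`: 1-(methoxycarbonyl)-2-methylpropyl in place of 1-(tert-butoxycarbonyl)ethyl on an amide-type nitrogen. In words, 1-(methoxycarbonyl)-2-methylpropyl stands in place of 1-(tert-butoxycarbonyl)ethyl on an amide-type nitrogen.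

Within the data shown here, only one measured step bears on this nitrogen, and it is modest: a 3.1-fold lower number from compound 1 to compound 2 (0.49 log units; beyond the scatter). That step swaps hexyl for an ester-bearing group, whereas the coming change swaps one ester-bearing group for another. Among the measured compounds shown here, no measured step covers such a swap, so the guide is weak. As far as these compounds go, no clear step beyond the scatter is therefore expected in this assay, and the direction stays open.

The expected step is a 1.2-fold higher number from compound 2 to compound 3 (0.08 log units; within the scatter). For compound 3 the estimated value is 3000 nM, with an expected range of 1000 nM to 9000 nM.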

Compound 3, half-maximal inhibitory concentration: > 62500 nM
Compound 3 ended at the assay's limit; the forecaster's own chance of this, stated with the estimate: 5%; middle value at least 20-fold (1.31 log units) away from the limit.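

In this assay compound 3 reads only as a limit of the assay, not as a number: the limit of > 62500 nM in this assay, at which 1 of the 3 values shown sits. Putting 1-(methoxycarbonyl)-2-methylpropyl in place of 1-(tert-butoxycarbonyl)ethyl on the amide-type nitrogen gives an at least 25-fold higher number from compound 2 to compound 3 (1.39 log units; beyond the scatter), so this nitrogen does not treat all ester-bearing groups alike, which compound 1 and compound 2 alone could not show. Putting the same group in place of hexyl gives an at least 8.0-fold higher number from compound 1 to compound 3 (0.90 log units; beyond the scatter), so an ester-bearing group at this nitrogen does not by itself bring the lower number of compound 2.

The ester and the side chain change together here, and the compounds shown do not separate the two. Also open, as far as these compounds go, is how a tert-butyl ester on the branched chain of compound 3, or a carboxylic acid in place of its ester, would read.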